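The source may report more compounds than this note shows. Statements on the series, on what has been measured and on what is new or still open speak of the compounds shown alone.

Notes on the sulfur substituent, read in a physicochemical assay for solubility; on this read-out higher numbers stand for higher solubility and lower numbers for lower solubility. Compound 3 `CSc1c(O)nc2ccc(C(F)(F)F)cc2c1-c1cc(Cl)ccc1O` reads < 1 ug/mL, which is a limit and not a number. Compound 1 `CC(C)(C)Sc1c(O)nc2ccc(C(F)(F)F)cc2c1-c1cc(Cl)ccc1O` reads < 1 ug/mL, likewise a limit. For the measured compounds named here, compound 2 `Oc1ccc(Cl)cc1-c1c(S)c(O)nc2ccc(C(F)(F)F)cc12` gives 30 ug/mL, the only true number in the set. The low end of the series is therefore set by the limit of < 1 ug/mL in this assay, at which 2 of the 3 values shown sit.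

Compound 4 `OCCSc1c(O)nc2ccc(C(F)(F)F)cc2c1-c1cc(Cl)ccc1O` carries the change (hydroxymethyl in place of hydrogen on a saturated chain carbon bound to a sulfur), which turns methyl to 2-hydroxyethyl on the sulfur. Going by the values given here, no measured step makes this exact change. The nearest evidence is an at least 30-fold lower number from compound 2 to compound 3 (1.47 log units; beyond the scatter), a large step, and an at least 30-fold higher number from compound 1 to compound 2 (1.47 log units; beyond the scatter), equally large, while a step that the two limits leave unreadable from compound 1 to compound 3 cannot be sized. Both compound 1 and compound 3, with carbon groups on the sulfur, stay at the limit, so compound 4 is expected to remain close to it. Compound 4 is not expected to approach compound 2 at 30 ug/mL. The expected change is small and upward, given as an at least 2.0-fold higher number from compound 3 to compound 4 (0.30 log units; that floor lies within the scatter). For compound 4 the estimate is 2 ug/mL, with an expected range of 0.6 ug/mL to 10 ug/mL.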

Compound 4, solubility: 4 ug/mL
Estimate against measurement, compound 4: 2.0-fold (0.30 log units) below, within the range that was stated.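

In this assay, hydroxymethyl in place of hydrogen on a saturated chain carbon bound to a sulfur gives an at least 4.0-fold higher number from compound 3 to compound 4 (0.60 log units; beyond the scatter), so a carbon chain on the sulfur can read clear of the limit, which compound 1 and compound 3 alone did not show. The 2-hydroxyethyl group likewise gives an at least 4.0-fold higher number from compound 1 to compound 4 (0.60 log units; beyond the scatter), yet hydrogen on the sulfur still stands apart, with a 7.5-fold lower number from compound 2 to compound 4 (0.88 log units; beyond the scatter). Two of these steps start from a limit, so they are floors and their full size stays unknown: the limit of < 1 ug/mL in this assay, at which 2 of the 4 values shown sit.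

The compounds shown leave open whether the hydroxyl end or the added chain length carries the step. They also leave open whether an amine or a carboxylic acid at the chain end, or a longer chain ending in a hydroxyl, would read closer to compound 2.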